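Chain lengthening on two cores: what an added methyl did

The compounds below may be only part of what the source reports. "The series", "measured", "known", "first", "only" and "open" are said of these compounds alone.

Measured so far, in a functional assay on the whole organism for inhibition, with Rattus norvegicus as the target, at a dose of 0.3 mg/kg by the oral route; a higher number here means a stronger effect of the compound at the dose given, a lower number a weaker effect:
compound 1, `COc1cc(C(=O)Nc2nn[nH]n2)nc(-c2ccc(C)cc2)c1`, gives 16%;
compound 2, `CCOc1cc(C(=O)Nc2nn[nH]n2)nc(-c2ccc(C)cc2)c1`, gives 26%;
compound 3, `CCCc1ccc(-c2cc(C)cc(C(=O)Nc3nn[nH]n3)n2)cc1`, gives 19%.

Compound 2 differs from compound 1 by methyl in place of hydrogen on a saturated chain carbon bound to an oxygen on an aromatic ring, and this step gave a number 10 percentage points higher from compound 1 to compound 2 (within the scatter). Compound 3 carries a different core; the difference between the two cores is not broken down here. Compound 4, `CCCCc1ccc(-c2cc(C)cc(C(=O)Nc3nn[nH]n3)n2)cc1`, is not yet measured; it differs from compound 3 by methyl in place of hydrogen on a saturated chain carbon, three bonds along the chain from an aromatic carbon. This is the same kind of change as from compound 1 to compound 2, though around the place it differs: there the carbon is bound to an oxygen on an aromatic ring, here it lies three bonds along the chain from an aromatic carbon. Because the earlier step gave a number 10 percentage points higher from compound 1 to compound 2 (within the scatter), a similarly small step is expected, a number 6 percentage points higher from compound 3 to compound 4 (within the scatter). Compound 4 is thus estimated at 25%, within 10% to 40%.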

Compound 4, a percentage reported as inhibition, in the whole organism at one dose (the size of the read-out at that dose, not a potency): 17%
The estimate for compound 4 lay 8 percentage points above the measured number; measured number inside the range.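

In this assay, going from propyl to butyl gave a number 2 percentage points lower from compound 3 to compound 4 (within the scatter). Set beside the earlier step, the added methyl shows no measurable difference between the two cores: the same change on two cores in this assay, a number 10 percentage points higher (within the scatter) from compound 1 to compound 2 and a number 2 percentage points lower (within the scatter) from compound 3 to compound 4, 12 percentage points apart, within the scatter of two such steps. This does not prove that the change acts identically on both cores or that it would carry to a third, for both steps are small and each rests on one dose.

The compounds shown leave open whether a longer chain than butyl, or an amine or a carboxylic acid in its place, would move the number beyond the scatter. They also leave open how the two cores compare directly, as no pair shown differs in the core alone.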